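Replacing a Hydrazide Ether with an Acrylamide Chain

This account rests on a few compounds, and the source may have more. Where it says the series, first, only, none or still open, it means among the compounds named here.

Measured compounds:
- compound 1, `O=C(/C=C/c1ccncc1-c1ccc2[nH]ccc2c1)N1CCOCC1`: 190 nM
- compound 2, `NNC(=O)COc1ccncc1-c1ccc2ccccc2c1`: "not determined" (no result reported)

In an assay on a protein complex for inhibition of CDK8/Cyclin C (Homo sapiens), with a stated time of 1 h (a higher number here means a weaker inhibitor, a lower number a stronger inhibitor), compound 1 gives 190 nM. Compound 2 was tested in the same way, but for compound 2 the result is "not determined" (no result reported), so compound 2 stands nowhere on this scale and offers no anchor for comparison.

Compound 3, `NC(=O)/C=C/c1ccncc1-c1ccc2ccccc2c1`, is the unmeasured partner of compound 2. The two differ in one place: 2-carbamoylethenyl in place of (aminocarbamoyl)methoxy on an aromatic carbon. Within the data shown here, since compound 2 has no value, no step between compound 2 and compound 3 can be given in this assay, and neither its size nor its direction can be read from the data.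

Among the measured compounds shown here, the only measured point is compound 1, and its value 190 nM is the reference for compound 3. Compound 3 is expected to give 300 nM, with a range from 60 nM to 1500 nM.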

Compound 3, half-maximal inhibitory concentration: 10.5 nM
Estimate against measurement, compound 3: 29-fold (1.46 log units) above; measured number below the stated range.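

Among these compounds, compound 2 has no number in this assay, so no step from it to compound 3 can be read. As far as these compounds go, what the change from (aminocarbamoyl)methoxy to 2-carbamoylethenyl does to the value in this assay stays open. No evidence bearing on this result is available.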